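A few compounds are considered here, and "the series" means these few. Any claim that something is new, unique, unknown or untested is made for them only; others in the source may bear on it.

For the measured compounds named here, in a functional assay on SK-MEL-28 cells (Homo sapiens) for inhibition (on this read-out lower numbers stand for stronger inhibition of growth and higher numbers for weaker inhibition of growth), compound 2 `COc1ccc(-n2cnnc2-c2cc(OC)c(OC)c(OC)c2)cc1O` gives 427 nM, the lower of the two numbers so far, while compound 1 `COc1ccc(-n2cnnc2-c2cc(OC)c(OC)c(OC)c2)cc1` gives 9550 nM. Compound 3 `COc1ccc(-n2cnnc2-c2cc(OC)c(OC)c(OC)c2)cc1F` has not yet been measured. It differs from compound 2 by one change, (fluoro in place of hydroxy on an aromatic carbon), with fluoro in place of hydroxy on an aromatic carbon, ortho to a methoxy group. Going by the values given here, one measured step bears on this: a 22-fold lower number from compound 1 to compound 2 (1.35 log units; beyond the scatter), a large step beyond the scatter, with hydroxy in place of hydrogen on that same carbon. Among the compounds with values here, compound 3 lacks that hydroxy, so part of this step may be lost, although no measured compound carries fluoro. A higher number is therefore expected in this assay, and the estimated step is a 7.0-fold higher number from compound 2 to compound 3 (0.85 log units; beyond the scatter). For compound 3 the expected value is 3000 nM, within an estimated range of 800 nM to 10000 nM.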

Compound 3, concentration for 50% growth inhibition: 39800 nM
Compound 3: middle estimate off by 13-fold (1.12 log units), on the low side, and the stated range ends below it.
By their numbers in this assay, from the lowest: compound 2; then compound 1; then compound 3.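

Fluoro does not stand in for hydroxy on this carbon, ortho to a methoxy group, in this assay: the exchange gives a 93-fold higher number from compound 2 to compound 3 (1.97 log units; beyond the scatter). It also differs from hydrogen, with a 4.2-fold higher number from compound 1 to compound 3 (0.62 log units; beyond the scatter), so the position responds in both directions, with hydroxy lowering the number and fluoro raising it, and compound 1 lying between them. Nothing available explains why these groups differ.

The three compounds cannot show whether the low number of compound 2 is particular to hydroxy, or whether an amine on the same carbon would also lower it. Nor do they show whether a chloro or a methyl group there would raise the number as fluoro does, or whether this ordering holds with other groups on the shared core.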